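The source may report more compounds than this note shows. Statements on the series, on what has been measured and on what is new or still open speak of the compounds shown alone.

Compound 1 `CCCCCCc1cn(C(c2ccccc2)c2ccccc2)nn1` was tested in an assay on isolated protein for inhibition of Aromatase (Homo sapiens), read by fluorescence and colorimetric assay, with a stated time of 30 min (a lower number here means a stronger inhibitor, a higher number a weaker inhibitor), and gave 14800 nM. Compound 2 `c1ccc(OCc2cn(C(c3ccccc3)c3ccccc3)nn2)cc1` differs from it in the chain alone, and in this assay compound 2 gives 31300 nM. Among the measured compounds shown here, the step of a 2.1-fold higher number from compound 1 to compound 2 (0.33 log units; beyond the scatter) is the only measured change so far. Of the two numbers at hand, compound 1 gives the lower one; the nearer is compound 2 with the higher number. Compound 3 `CCCCCCc1cn(Cc2ccccc2)nn1` has not yet been measured. It differs from compound 1 by hydrogen in place of phenyl on a saturated chain carbon bound to an aromatic carbon and an aromatic nitrogen. For the measured compounds named here, no measured step concerns this place in the molecule, so the step of a 2.1-fold higher number from compound 1 to compound 2 (0.33 log units; beyond the scatter) bears on it only by showing that a modest structural change can move the number in this assay beyond the scatter. The expected step is a 2.0-fold higher number from compound 1 to compound 3 (0.31 log units; beyond the scatter), a modest weakening. Compound 3 is therefore estimated at 30000 nM, within a range from 8000 nM to 120000 nM.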

Compound 3, half-maximal inhibitory concentration: 7470 nM
The estimate for compound 3 lay 4.0-fold (0.60 log units) above the measured number; measured number below the stated range.
By their numbers in this assay, from the lowest: compounds 3 and 1 (each within the scatter of the next); then compound 2.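

Taking the phenyl away from the saturated chain carbon bound to an aromatic carbon and an aromatic nitrogen, and leaving hydrogen there, gives a 2.0-fold lower number from compound 1 to compound 3 (0.30 log units; within the scatter) in this assay and so does not separate the two compounds. Among the compounds shown here, this phenyl, with its 6 heavy atoms, can therefore be lost from this place without a measurable difference, whereas the earlier compounds showed only a change in the chain at another place. No measurement at hand offers a reason for this result.

From the compounds shown here alone, it remains open whether a group other than phenyl or hydrogen at this carbon, such as a methyl or a carboxylic acid, would move the number beyond the scatter. Going by these compounds, it is also open whether phenoxy in place of pentyl would have the same effect on compound 3 as a 2.1-fold higher number from compound 1 to compound 2 (0.33 log units; beyond the scatter) does on compound 1.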